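The compounds below may be only part of what the source reports. "The series", "measured", "known", "first", "only" and "open" are said of these compounds alone.

The measured compounds in an assay on lysate for inhibition of 6-phosphofructo-2-kinase/fructose-2,6-bisphosphatase 3 (Homo sapiens), with stated times of 0.5 min and 45 min; on this read-out lower numbers stand for stronger inhibition and higher numbers for weaker inhibition:
Compound 1 `CN1CCC(CNS(=O)(=O)c2ccccc2Nc2cc(-c3ccc4ccn(C)c4c3)c3nccnc3c2)C1`: 4640 nM
Compound 2 `Cn1cc(CNS(=O)(=O)c2ccccc2Nc2cc(-c3ccc4ccn(C)c4c3)c3nccnc3c2)cn1`: this value is a limit of the assay, > 100000 nM
Compound 3 `CN1CCC(NC(=O)c2ccncc2Nc2cc(-c3ccc4ccn(C)c4c3)c3nccnc3c2)CC1`: 19500 nM

Among the two numbers reported, compound 3 stands highest. Compound 1, with 4640 nM, gives the lower number, and compound 3, with 19500 nM, gives the higher one, a gap beyond the scatter. Compound 4 `CN1CCC(CNC(=O)c2ccncc2Nc2cc(-c3ccc4ccn(C)c4c3)c3nccnc3c2)C1` differs from compound 3 in one place: (1-methylpyrrolidin-3-yl)methyl in place of 1-methylpiperidin-4-yl on an amide-type nitrogen.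

Among the measured compounds shown here, only one measured step exists, an at least 21-fold higher number from compound 1 to compound 2 (1.33 log units; beyond the scatter), which concerns the group on a sulfonamide nitrogen and reaches the assay limit (the limit of > 100000 nM in this assay, at which 1 of the 3 values shown sits). It does not address the change from compound 3 to compound 4, where a 1-methylpiperidin-4-yl is exchanged for a (1-methylpyrrolidin-3-yl)methyl on an amide-type nitrogen. For the measured compounds named here, the only hint is that compound 1, which carries the entering group on a sulfonamide, gives the lower number of the two, whereas compound 3 carries the leaving group. Compound 4 is therefore expected to give a modestly lower number, a 1.8-fold lower number from compound 3 to compound 4 (0.25 log units; within the scatter), a step not clearly beyond the scatter. For compound 4 the estimate is 11000 nM, within 3500 nM to 35000 nM.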

Compound 4, half-maximal inhibitory concentration: 24000 nM
Compound 4: middle estimate off by 2.2-fold (0.34 log units), on the low side; the measured number falls inside the stated range.
By their numbers in this assay, from the lowest: compound 1; then compounds 3 and 4 (each within the scatter of the next). At a limit, above all of these: compound 2.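

In this assay, the exchange on an amide-type nitrogen gives a 1.2-fold higher number from compound 3 to compound 4 (0.09 log units; within the scatter), so the two groups cannot be told apart here. Among the compounds shown here, a six-membered non-aromatic ring in 1-methylpiperidin-4-yl and a five-membered one in (1-methylpyrrolidin-3-yl)methyl, both with the same atoms, read alike at this position, which the earlier compounds could not show. Nothing among the data offered bears on why these two groups read alike.

Still open, going by these compounds, is whether the ring matters at all on this amide-type nitrogen, which an open-chain group such as 2-(dimethylamino)ethyl or a ring such as morpholine would address. Also open, on these data alone, is how a carboxylic acid or a longer chain ending in an amine would read at this same position.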